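Fluorine and Methoxy Added to the Phenyl Arm

The compounds below may be only part of what the source reports. "The series", "measured", "known", "first", "only" and "open" are said of these compounds alone.

In a functional assay on A549 cells (Homo sapiens) for inhibition, read by CCK-8 assay, with a stated time of 48 h (on this read-out higher numbers stand for weaker inhibition and lower numbers for stronger inhibition), compound 1 `COc1cc(-c2ccnc3cc(-c4ccccc4)nn23)cc(OC)c1OC` gives 208 nM, the lowest of the two numbers at hand. Compound 2 `COc1cc(-c2ccnc3cc(-c4cccc5c4ccn5CO)nn23)cc(OC)c1OC` gives 1100 nM in this assay, a higher number that lies beyond the usual scatter.

Compound 3 `COc1ccc(-c2cc3nccc(-c4cc(OC)c(OC)c(OC)c4)n3n2)cc1F` is not yet measured. It differs from compound 1 in one place: 3-fluoro-4-methoxyphenyl in place of phenyl on an aromatic carbon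

For the measured compounds named here, no step between measured compounds bears on this change, so the direction must be judged from compound 1 alone. A small step is expected from compound 1 to compound 3, towards a lower number in this assay, as estimated at a 1.4-fold lower number from compound 1 to compound 3 (0.14 log units; within the scatter), but one that may well fall within the scatter. Compound 3 is therefore expected to give about 150 nM in this assay, with a plausible range from 40 nM to 600 nM.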

Compound 3, half-maximal inhibitory concentration: 545 nM
Estimate against measurement, compound 3: 3.6-fold (0.56 log units) below; measured number inside the range.
By their numbers in this assay, from the lowest: compound 1; then compounds 3 and 2 (each within the scatter of the next).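

In this assay, 3-fluoro-4-methoxyphenyl in place of phenyl on this aromatic carbon of the five-membered ring brings a 2.6-fold higher number from compound 1 to compound 3 (0.42 log units; beyond the scatter), a modest step. It is the only single change read at this position among the compounds shown, and here the plain phenyl of compound 1 keeps the lower number, so adding fluorine and methoxy to this arm does not bring the number down. Nothing available explains the size or direction of this step.

The change adds fluorine and methoxy together, so the pair leaves open which of the two carries the step, a question that 3-fluorophenyl and 4-methoxyphenyl would each help to answer. Also open, from the compounds shown here alone, is how a dimethylamino group or a carboxylic acid on the same phenyl arm would read in this assay.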